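Swapping Bromo for Nitro on the Shared Core

The source may hold more compounds than are shown below. What is called first, only, known or untested is meant among the compounds shown, and "the series" means these compounds.

Of the compounds shown here, three built on one shared core have been tested in a functional assay on the whole organism for inhibition, with Rattus norvegicus as the target, read by paw edema, with a stated time of 30 min, at a dose of 20 mg/kg by the oral route; a higher number here means a stronger effect of the compound at the dose given, a lower number a weaker effect. Compound 1 `COc1ccc(OCC2=NCCO2)cc1` gives 16.6%. Compound 2 `Brc1ccccc1OCC1=NCCO1` gives 20.1%, and compound 3 `Brc1ccc(OCC2=NCCO2)cc1` gives 35.5%. On these numbers compound 2 stands second highest of the three: its value and that of compound 1 lie within the scatter of each other, while the value of compound 3 lies above it by more than the scatter. For the measured compounds named here, the only step between compounds that differ in a single place, a number 18.9 percentage points higher from compound 1 to compound 3 (beyond the scatter), is a modest rise.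

Compound 4 `O=[N+]([O-])c1ccccc1OCC1=NCCO1` has not yet been measured. It differs from compound 2 in one place: nitro in place of bromo on an aromatic carbon. Going by the values given here, no measured step involves a nitro group, so none bears directly on this change; the one known step concerns a different swap. With no guide in either direction, the expected step of a number 1.9 percentage points higher from compound 2 to compound 4 (within the scatter) is small and may well stay within the scatter. Compound 4 is therefore estimated at 22% in this assay, with a range from 8% to 38%.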

Compound 4, a percentage reported as inhibition, in the whole organism at one dose (the size of the read-out at that dose, not a potency): 20.5%
Beside the measured number, compound 4's estimate is 1.5 percentage points above it, within the range that was stated.
By their numbers in this assay, from the lowest: compounds 1, 2 and 4 (each within the scatter of the next); then compound 3.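

In this assay, nitro in place of bromo on an aromatic carbon, ortho to a group of 7 heavy atoms, gives a number 0.4 percentage points higher from compound 2 to compound 4 (within the scatter), so this read-out does not separate the two groups at this position. The change is not small in atom count: bromo is 1 heavy atom with 0 hydrogen-bond acceptors, while nitro is 3 heavy atoms with 2 hydrogen-bond acceptors, yet the step stays within the scatter. No measurement presented here offers an explanation for this result.

Going by these compounds, whether an amine or a carboxylic acid at this same position would also stay within the scatter of compound 2 remains open. Also open, on these data alone, is whether the same swap of bromo for nitro, made on compound 3, would give an equally small step.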